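The source may hold more compounds than are shown below. What is called first, only, known or untested is meant among the compounds shown, and "the series" means these compounds.

Compound 1 `COc1cc2c(Oc3ccc(NC(=O)c4cn(-c5ccccc5Cl)nn4)cc3F)ccnc2cc1OCCCN1CCCC1` — 70 nM in a functional assay on MKN-45 cells (Homo sapiens) for cytotoxicity, read by MTT assay, with a stated time of 72 h; on this read-out higher numbers stand for weaker inhibition and lower numbers for stronger inhibition
Compound 2 `COc1cc2c(Oc3ccc(NC(=O)c4cn(-c5ccccc5C)nn4)cc3F)ccnc2cc1OCCCN1CCCC1` — "not determined" (no result reported) in this assay

Compound 2 stands nowhere on the numbers shown, as its result in this assay reads "not determined" (no result reported). Compound 3 `COc1cc2c(Oc3ccc(NC(=O)c4cn(-c5ccc(Br)cc5)nn4)cc3F)ccnc2cc1OCCCN1CCCC1` differs from compound 2 by 4-bromophenyl in place of 2-methylphenyl on an aromatic nitrogen. No measured step of this kind exists among these compounds, so the size of the change cannot be read from the data; with compound 1 giving 70 nM on the shared core, compound 3 is expected to land near that level, with no step beyond the scatter. Compound 3 is expected to give about 100 nM in this assay, within a range from 25 nM to 500 nM.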

Compound 3, half-maximal inhibitory concentration: 120 nM
Compound 3: middle estimate off by 1.2-fold (0.08 log units), on the low side, and the stated range covers the measured number.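

On this aromatic nitrogen, 4-bromophenyl in place of 2-chlorophenyl gives a 1.7-fold higher number from compound 1 to compound 3 (0.23 log units; within the scatter) in this assay, so this swap leaves the number within the usual scatter. The swap alters both the halogen and its place on the phenyl ring, and these two compounds cannot separate the two. Nothing given here accounts for the result.

The step from compound 2 to compound 3 cannot be read, so 2-methylphenyl remains unplaced. Going by these compounds, whether an amine or a carboxylic acid on this phenyl ring would hold this level remains open.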